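A 4-Methylphenyl Swap Among Compounds at a Limit

A few compounds are considered here, and "the series" means these few. Any claim that something is new, unique, unknown or untested is made for them only; others in the source may bear on it.

In a functional assay on HEK293 cells (Homo sapiens) for cytotoxicity (a lower number here means that less compound is tolerated, a higher number that more compound is tolerated), compound 3, `COc1ccc([C@H]2CC(=O)N(c3cccc(C#N)c3)C2)cc1OC1CCCC1`, gives only a limit, > 10000 nM. Compound 1, `COc1ccc([C@H]2CC(=O)N(C(=O)c3ccccc3)C2)cc1OC1CCCC1`, also gives only a limit, > 10000 nM. Compound 2, `COc1ccc([C@H]2CC(=O)N(c3ccc(C)c(N)c3)C2)cc1OC1CCCC1`, likewise gives only a limit, > 10000 nM. All three therefore sit together: the limit of > 10000 nM in this assay, at which 3 of the 3 values shown sit.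

Compound 4, `COc1ccc([C@H]2CC(=O)N(c3ccc(C)cc3)C2)cc1OC1CCCC1`, keeps the shared core and changes one group: 4-methylphenyl in place of 3-cyanophenyl on an amide-type nitrogen in a ring. It carries 4-methylphenyl in place of 3-cyanophenyl on an amide-type nitrogen in a ring.

The measured steps at this same nitrogen are the closest guide: a step that the two limits leave unreadable from compound 1 to compound 2, a step that the two limits leave unreadable from compound 1 to compound 3 and a step that the two limits leave unreadable from compound 2 to compound 3. None has a readable size, yet none of these groups gave a number in this assay. A step of readable size is therefore not expected, and no direction can be given. The expected step is a step that the limit leaves unreadable from compound 3 to compound 4. For compound 4 the estimated value is 15000 nM, with an expected range from 7000 nM to 30000 nM. The most likely report is again only a limit.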

Compound 4, half-maximal cytotoxic concentration: > 10000 nM
Compound 4: a limit, no number; the forecaster's own chance of this, stated with the estimate: 90%; the middle value is on the limit's open side.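

In this assay compound 4 gives > 10000 nM, which is again only a limit. No step to compound 4 from compound 1, compound 2 or compound 3 can be read: the limit of > 10000 nM in this assay, at which 4 of the 4 values shown sit.

The compounds shown leave open how much compound each one's cells would tolerate, and whether these groups differ at all in this assay.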